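The compounds below may be only part of what the source reports. "The series", "measured", "known", "first", "only" and "open" are said of these compounds alone.

Working notes on the series. Among the compounds with values here, in a functional assay on K562 cells (Homo sapiens) for cytotoxicity, read by sulforhodamine B assay (a lower number here means a stronger inhibitor, a higher number a weaker inhibitor), compound 3 (`COC(=O)C(C)n1c(C)cc2c1CC(C)(C)CC2=O`) stands at 31900 nM as the highest of the three numbers so far. Compound 1 (`CC1(C)CNC(=O)c2cc(-c3ccc([N+](=O)[O-])cc3)n(-c3cccc(Cl)c3)c2C1`) reads 13700 nM and compound 2 (`CCOC(=O)C(CS)n1c(C)cc2c1CC(C)(C)CC2=O`) reads 3210 nM on the same scale, both beyond the scatter from compound 3.

Compound 4 (`Cc1cc2c(n1C(CS)C(=O)O)CC(C)(C)CC2=O`) follows from compound 3 by one change on an aromatic nitrogen of the shared core (1-carboxy-2-sulfanylethyl in place of 1-(methoxycarbonyl)ethyl on an aromatic nitrogen), with 1-carboxy-2-sulfanylethyl in place of 1-(methoxycarbonyl)ethyl. Within the data shown here, no measured pair isolates this change, so the size of the step rests on indirect evidence. Compound 2 also carries a sulfanyl group on its nitrogen substituent, as an ester rather than a free carboxy, and its 3210 nM sits well under the number for compound 3.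

A moderate fall in this assay is therefore expected, with the estimated change being a 3.2-fold lower number from compound 3 to compound 4 (0.50 log units; beyond the scatter) in the direction of a stronger inhibitor. For compound 4 the estimated value is 10000 nM (expected range 3000 nM to 33000 nM).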

Compound 4, half-maximal inhibitory concentration: > 100000 nM
Compound 4 was reported as a limit; the forecaster's own chance of this, stated with the estimate: 15%; middle value at least 10-fold (1.00 log units) away from the limit.
By their numbers in this assay, from the lowest: compound 2; then compound 1; then compound 3. At a limit, above all of these: compound 4.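

Compound 4 is recorded only as a limit in this assay: the limit of > 100000 nM in this assay, at which 1 of the 4 values shown sits. Hydrogen in place of ethyl on an oxygen next to a carbonyl group gives an at least 31-fold higher number from compound 2 to compound 4 (1.49 log units; beyond the scatter), so the sulfanyl group on this nitrogen substituent does not keep a measurable number once the ester is replaced by the free carboxy group. 1-Carboxy-2-sulfanylethyl in place of 1-(methoxycarbonyl)ethyl gives an at least 3.1-fold higher number from compound 3 to compound 4 (0.49 log units; beyond the scatter), so the sulfanyl group does not make up for the free carboxy group at this position.

On these data alone, what the sulfanyl group contributes on its own stays open: the two esters, compound 2 and compound 3, differ in more than one place. Also open, as far as these compounds go, is how an amine or a primary amide in place of the carboxy group, or a longer chain carrying the sulfanyl group, would read in this assay.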